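Replacing Chloro with Methyl in a Carbamoyl-Bearing Core

The source may report more compounds than this note shows. Statements on the series, on what has been measured and on what is new or still open speak of the compounds shown alone.

Three compounds have been examined in an assay on isolated protein for inhibition of Nicotinamide N-methyltransferase (Homo sapiens), read by luminescence, with a stated time of 20 min; a higher number here means a weaker inhibitor, a lower number a stronger inhibitor. In this assay compound 1 `O=C1NCCc2ncccc21` gives no result reported. Within the data shown here, compound 2 `NC(=O)c1cnc2c(c1Cl)CCN2` gives 92 nM in this assay, the only single number among the three. In this assay compound 3 `CNc1ncc(C(N)=O)s1` gives only a limit of the assay, > 10000 nM. Among the measured compounds shown here, compound 2 thus stands as the sole compound with a measured potency. Compound 4 `Cc1c(C(N)=O)cnc2c1CCN2` differs from compound 2 by methyl in place of chloro on an aromatic carbon. For the measured compounds named here, no step between two measured compounds is available to gauge such a change, so the expectation rests on compound 2 alone: the change is expected to bring a 1.3-fold higher number from compound 2 to compound 4 (0.12 log units; within the scatter), a step in this assay of no more than the usual scatter and in no particular direction. Compound 4 is estimated at 120 nM, within a range of 40 nM to 400 nM.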

Compound 4, half-maximal inhibitory concentration: 102 nM
Compound 4: the middle estimate sits 1.2-fold (0.07 log units) above what was measured; measured number inside the range.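

In this assay, the aromatic carbon ortho to the carbamoyl group and opposite the ring nitrogen carries either chloro or methyl with no change that can be told from scatter: a 1.1-fold higher number from compound 2 to compound 4 (0.04 log units; within the scatter). The potency of compound 2 therefore does not rest on chloro as such, at least against a methyl group of equal heavy-atom count. Nothing measured here bears on why the two groups match. Still open, from the compounds shown here alone, is how this position responds to a hydrogen, a methoxy group, an amine or a longer chain such as ethyl. Also open, going by these compounds, is whether a carboxylic acid or a nitrile could stand in for the carbamoyl group on the shared core.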